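This account rests on a few compounds, and the source may have more. Where it says the series, first, only, none or still open, it means among the compounds named here.

The measured compounds:
compound 1, `COc1n[nH]c2ncc(C#Cc3c(F)ccc(NS(=O)(=O)c4cccc(Cl)c4)c3F)cc12`, 4.2 nM
compound 2, `COc1n[nH]c2ncc(C#Cc3c(F)ccc(NS(=O)(=O)c4cccc(C)c4)c3F)cc12`, 12.1 nM
compound 3, `COc1n[nH]c2ncc(C#Cc3c(F)ccc(NS(=O)(=O)c4cccc(Br)c4)c3F)cc12`, 5 nM

In an assay on cells for inhibition of mitogen-activated protein kinase kinase kinase 20 (Homo sapiens), read by ADP-Glo, with a stated time of 30 min (a lower number here means a stronger inhibitor, a higher number a weaker inhibitor), compound 1 gives the lowest number of the three, though compound 3 sits within the scatter of it, with a 1.2-fold higher number from compound 1 to compound 3 (0.08 log units; within the scatter). Compound 2 stands furthest from compound 1, with a 2.9-fold higher number from compound 1 to compound 2 (0.46 log units; beyond the scatter). Between compound 2 and compound 3 the step is a 2.4-fold lower number from compound 2 to compound 3 (0.38 log units; beyond the scatter).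

Compound 4, `COc1n[nH]c2ncc(C#Cc3c(F)ccc(NS(=O)(=O)c4cccc(Cl)c4Cl)c3F)cc12`, has not yet been measured in this assay. It differs from compound 1 by chloro in place of hydrogen on an aromatic carbon. The three measured steps all exchange one group for another at a single aromatic carbon; none adds a second chloro to the (3-chlorophenyl)sulfonyl group. They show only that chloro or bromo there gives a lower number than methyl, and that chloro and bromo are within the scatter of each other. A second chloro has no direct precedent among these compounds, so compound 4 is expected to stay close to compound 1, with the step of a 1.2-fold higher number from compound 1 to compound 4 (0.08 log units; within the scatter) not expected to pass beyond the scatter. The estimate for compound 4 in this assay is 5 nM, ranging from 2 nM to 13 nM.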

Compound 4, half-maximal inhibitory concentration: 9.6 nM
Compound 4: the middle estimate sits 1.9-fold (0.28 log units) below what was measured; the measured number falls inside the stated range.
By their numbers in this assay, from the lowest: compounds 1, 3, 4 and 2 (each within the scatter of the next, the first and the last beyond it).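

Within the data shown here, compound 4 shows that this position does not accept a second substituent without cost: placing chloro on the aromatic carbon ortho to a chloro group gives a 2.3-fold higher number from compound 1 to compound 4 (0.36 log units; beyond the scatter) in this assay as a modest step beyond the scatter, whereas the earlier compounds only exchanged one group for another at a single carbon. The 2,3-dichlorophenyl group does not separate compound 4 from the two single-substituent analogues, since a 1.9-fold higher number from compound 3 to compound 4 (0.28 log units; within the scatter) and a 1.3-fold lower number from compound 2 to compound 4 (0.10 log units; within the scatter) both lie within the scatter. Nothing available here accounts for the step from the 3-chlorophenyl to the 2,3-dichlorophenyl group.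

As far as these compounds go, whether this step is particular to chloro remains open, since fluoro, methoxy or an amine on that same carbon could give a different number. Also open, from the compounds shown here alone, is whether the 3-chloro group must remain when that carbon is substituted.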